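A few compounds are considered here, and "the series" means these few. Any claim that something is new, unique, unknown or untested is made for them only; others in the source may bear on it.

Measured compounds: compound 1 `CC[C@H]1CN(c2nc(N)c(C(N)=O)nc2Cl)CCN1C1CCN(C(=O)c2ccc(Cl)cc2)CC1`, compound 2 `CC[C@H]1CN(c2ncc(C(N)=O)nc2C(F)(F)F)CCN1C1CCN(C(=O)c2ccc(Cl)nc2N)CC1`, compound 3 `CC[C@H]1CN(c2ncc(C(N)=O)nc2C)CCN1C1CCN(C(=O)c2ccc(Cl)nc2N)CC1`. In an in vitro assay on BaF3 cells for displacement of a labelled ligand from C-X-C chemokine receptor type 3 (Homo sapiens) (on this read-out higher numbers stand for weaker inhibition and lower numbers for stronger inhibition), compound 1 gives 76 nM, compound 2 gives 1.9 nM, and compound 3 gives 4 nM.

Among the compounds with values here, compound 3 stands second of the three numbers; its nearest neighbour is compound 2, and the only one-place step among the measured compounds is a 2.1-fold higher number from compound 2 to compound 3 (0.32 log units; beyond the scatter). Compound 1 is the furthest from compound 3.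

Compound 4 `CC[C@H]1CN(c2ncc(C(N)=O)nc2C)CCN1C1CCN(C(=O)c2ccc(Cl)cc2)CC1` has not been measured. It differs from compound 3 by 4-chlorophenyl in place of 2-amino-6-chloropyridin-3-yl on a carbonyl carbon. Within the data shown here, no measured pair differs in this place alone, so no step bears directly on it. Among the measured compounds shown here, the only measured compound carrying the 4-chlorophenyl is compound 1, whose value in this assay lies well above that of compound 3; but compound 1 also differs from compound 3 in the substituents on the shared core, so its gap cannot be assigned to the aroyl group alone.

For the measured compounds named here, since the loss of the 2-amino-6-chloropyridin-3-yl has no measured counterpart, the expectation for compound 4 is uncertain; a rise in the number is expected, of about a 5.0-fold higher number from compound 3 to compound 4 (0.70 log units; beyond the scatter). The estimate for compound 4 in this assay is 20 nM, within 6 nM to 70 nM.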

Compound 4, half-maximal inhibitory concentration: 18 nM
The estimate for compound 4 lay 1.1-fold (0.05 log units) above the measured number; the range from low to high includes it.
By their numbers in this assay, from the lowest: compound 2; then compound 3; then compound 4; then compound 1.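

In this assay, the aroyl position now has a direct read: a 4.5-fold higher number from compound 3 to compound 4 (0.65 log units; beyond the scatter), with 4-chlorophenyl in place of 2-amino-6-chloropyridin-3-yl on a carbonyl carbon, so on this core the change costs a modest but real amount. Compound 4 also links compound 1 to the rest of the series, since a 4.2-fold lower number from compound 1 to compound 4 (0.63 log units; beyond the scatter) with 5-carbamoyl-3-methylpyrazin-2-yl in place of 6-amino-5-carbamoyl-3-chloropyrazin-2-yl on an amine nitrogen in a ring, so each of the two places carries a modest step of its own, beyond the scatter. Nothing available explains either step.

As far as these compounds go, the aroyl step is read on one core only, so its size with the trifluoromethyl of compound 2 remains open, and the pyrazinyl step bundles the amino group with the chlorine-to-methyl change, leaving the two unseparated. From the compounds shown here alone, it is also open how a bromine or a nitrile in place of the chlorine on the aroyl ring would read, with or without the amino group.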